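The source may hold more compounds than are shown below. What is called first, only, known or untested is meant among the compounds shown, and "the series" means these compounds.

Series notes. For the measured compounds named here, compound 3 `CCCn1c(=O)[nH]c2nc(-c3ccc(S(=O)(=O)N4CCN(c5cccc(F)c5)CC4)cc3)[nH]c2c1=O` gives the highest of the three numbers measured so far: in an assay on CHO cells for displacement of a labelled ligand from adenosine receptor A3 (Homo sapiens), read by scintillation counting, with a stated time of 45 min, tested at 1 uM, in the presence of a further agent that is not named here (on this read-out lower numbers stand for less inhibition and higher numbers for more inhibition at the one concentration tested (going by the name of the read-out)), compound 3 gives 44%. Compound 1 `CCCn1c(=O)[nH]c2nc(-c3ccc(S(=O)(=O)N4CCN(c5ccccc5C)CC4)cc3)[nH]c2c1=O` gives 25% and compound 2 `CCCn1c(=O)[nH]c2nc(-c3ccc(S(=O)(=O)N4CCN(c5ccccc5F)CC4)cc3)[nH]c2c1=O` gives 9% in this assay. Compound 4 `CCCn1c(=O)[nH]c2nc(-c3ccc(S(=O)(=O)N4CCN(Cc5ccc(Br)cc5)CC4)cc3)[nH]c2c1=O` differs from compound 3 by 4-bromobenzyl in place of 3-fluorophenyl on an amine nitrogen in a ring. The measured steps that touch the same ring nitrogen bear on this: a number 19 percentage points higher from compound 1 to compound 3 (beyond the scatter) and a number 35 percentage points higher from compound 2 to compound 3 (beyond the scatter); the step of a number 16 percentage points lower from compound 1 to compound 2 (beyond the scatter) shows that a single change on the aryl group also moves the number. None of these exchanges an aryl group for a benzyl group, so the direction is uncertain; a modest downward step, a number 14 percentage points lower from compound 3 to compound 4 (beyond the scatter), is expected. Compound 4 is estimated at 30%, within 5% to 60%.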

Compound 4, a percentage reported as inhibition, at one concentration (the size of the read-out at that concentration, not a potency): 28%
Estimate against measurement, compound 4: 2 percentage points above; the measured number falls inside the stated range.
By their numbers in this assay, from the lowest: compound 2; then compounds 1 and 4 (each within the scatter of the next); then compound 3.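

On the ring nitrogen, the change from an aryl group to 4-bromobenzyl leaves the number within the range of the aryl compounds in this assay (a number 16 percentage points lower from compound 3 to compound 4 (beyond the scatter); a number 19 percentage points higher from compound 2 to compound 4 (beyond the scatter); a number 3 percentage points higher from compound 1 to compound 4 (within the scatter)). The benzyl linkage therefore does not by itself take the number outside that range, and 4-bromobenzyl cannot be told apart from 2-methylphenyl here. No measurement bears on why these groups differ. Open, as far as these compounds go, is whether the bromine or the benzyl linkage sets the number; an unsubstituted benzyl or 3-fluorobenzyl group on this nitrogen would separate the two.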